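The source may hold more compounds than are shown below. What is called first, only, known or untested is meant among the compounds shown, and "the series" means these compounds.

Compound 1, `CC/N=C(\S)OC[C@H]1OC(n2cnc3c(NC4CCOC4)nc(Cl)nc32)[C@H](O)[C@@H]1O`, in an assay on DDT1 cells (Cricetulus griseus) for binding affinity to adenosine receptor A1 (Homo sapiens), read by radioligand binding (a higher number here means a weaker inhibitor, a lower number a stronger inhibitor), gives 55 nM.
Compound 2, `CCCC/N=C(\S)OC[C@H]1OC(n2cnc3c(NC4CCOC4)ncnc32)[C@H](O)[C@@H]1O`, in this assay gives 157 nM.

Going by the values given here, of the two numbers so far, compound 2 holds the higher one; compound 1 sits lower, and the gap between them lies beyond the usual scatter. The two compounds differ in more than one place, so that gap cannot be pinned on a single change.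

Compound 3, `C=CC/N=C(\S)OC[C@H]1OC(n2cnc3c(NC4CCOC4)ncnc32)[C@H](O)[C@@H]1O`, has not yet been tested. It differs from compound 2 in one place: vinyl in place of propyl on a saturated chain carbon bound to a double-bonded nitrogen. Among the compounds with values here, nothing among the measured pairs isolates this change, so no step can be read directly from the data. Compound 1, which carries a shorter chain at the same place, gives the lower number of the two, but it also carries a chlorine on the core, so that comparison is not clean.

The expectation for compound 3 is a small step from compound 2 toward a lower number, a 1.6-fold lower number from compound 2 to compound 3 (0.20 log units; within the scatter), which may well stay within the scatter. Compound 3 is estimated at 100 nM, with a range from 40 nM to 250 nM.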

Compound 3, inhibition constant: 35 nM
Compound 3: middle estimate off by 2.9-fold (0.46 log units), on the high side; the whole stated range lies above it.
By their numbers in this assay, from the lowest: compounds 3 and 1 (each within the scatter of the next); then compound 2.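

Read in this assay, the exchange of propyl for vinyl on a saturated chain carbon bound to a double-bonded nitrogen, which cut one bond further out reads butyl to allyl, gives the first clean measure of this position (a 4.5-fold lower number from compound 2 to compound 3 (0.65 log units; beyond the scatter)), and this step lies beyond the usual scatter. The earlier pair could not show this, since compound 1 and compound 2 differ in more than one place, whereas here the chain alone changes and the number clearly responds. Even so, the change removes a carbon and brings in a double bond together, and nothing available explains the size of the step.

The compounds shown do not separate the loss of chain length from the gain of the double bond, and a benzyl or cyclopropylmethyl group in place of the allyl could test how far the response at this position extends. The effect of the chlorine on the core of compound 1 cannot be read either, as no pair isolates it, and the same holds for every other comparison among these three compounds.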